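A few compounds are considered here, and "the series" means these few. Any claim that something is new, unique, unknown or untested is made for them only; others in the source may bear on it.

In a functional assay on HT-1080 cells (Homo sapiens) for antiproliferative activity, read by MTT assay, with a stated time of 72 h (on this read-out higher numbers stand for weaker inhibition and lower numbers for stronger inhibition), compound 1 `COc1ccc(-c2cc(C(=O)O)sc2-c2cc(OC)c(OC)c(OC)c2)cc1` gives 5810 nM. Compound 3 `COc1ccc(-c2ccsc2-c2cc(OC)c(OC)c(OC)c2)cc1`, which has no carboxy group, gives 3620 nM. The difference is a 1.6-fold lower number from compound 1 to compound 3 (0.21 log units; within the scatter), and the two stand level. Compound 2 `COc1ccc(-c2cc(C(=O)O)sc2-c2cc(OC)c(OC)c(OC)c2)cc1OCc1ccccc1` gives only a limit of the assay, > 100000 nM. Compound 4 `COc1ccc(-c2ccsc2-c2cc(OC)c(OC)c(OC)c2)cc1OCc1ccccc1` departs from compound 3 by benzyloxy in place of hydrogen on an aromatic carbon, with benzyloxy in place of hydrogen on an aromatic carbon, ortho to a methoxy group. From the compounds shown here alone, the same exchange has been measured once, as an at least 17-fold higher number from compound 1 to compound 2 (1.23 log units; beyond the scatter), and that large step ends at a limit, so its full size is unknown. Among the compounds with values here, with it as the only guide, a large rise in this assay is expected, though the size remains open without the carboxy group. The expected step is an 8.3-fold higher number from compound 3 to compound 4 (0.92 log units; beyond the scatter). Compound 4 is estimated at 30000 nM, within a range of 6000 nM to 100000 nM.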

Compound 4, half-maximal inhibitory concentration: > 100000 nM
Compound 4: no number, only a limit; the forecaster's own chance of this, stated with the estimate: 40%; middle value at least 3.3-fold (0.52 log units) from the limit.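

In this assay, benzyloxy in place of hydrogen on an aromatic carbon, ortho to a methoxy group, also pushes the number up on the core without the carboxy group, giving an at least 27-fold higher number from compound 3 to compound 4 (1.44 log units; beyond the scatter). The large rise therefore appears both with and without the carboxy group: the same change on two cores in this assay, an at least 17-fold higher number (1.23 log units; beyond the scatter) from compound 1 to compound 2 and an at least 27-fold higher number (1.44 log units; beyond the scatter) from compound 3 to compound 4; the limit leaves it open whether they differ. The step between compound 2 and compound 4 cannot be read, since both values are limits: the limit of > 100000 nM in this assay, at which 2 of the 4 values shown sit.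

From the compounds shown here alone, the true size of both steps stays open. So does the outcome with hydroxy or ethoxy at this position, compared with compound 3 at 3620 nM.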